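Acetamido to Dimethylamino: From Compound 3 to Compound 4

This account rests on a few compounds, and the source may have more. Where it says the series, first, only, none or still open, it means among the compounds named here.

Compound 1 `COc1ccc(/C=C\c2cc(OC)c(OC)c(OC)c2)cc1OCc1ccc(CN2CCCCC2C(=O)NCCN)cc1` gives 7300 nM in a functional assay on HeLa cells (Homo sapiens) for antiproliferative activity, read by CCK-8 assay, with a stated time of 48 h; on this read-out lower numbers stand for stronger inhibition and higher numbers for weaker inhibition.
Compound 2 `COc1ccc(/C=C\c2cc(OC)c(OC)c(OC)c2)cc1OCc1ccc(CN[C@H](C(=O)O)[C@@H](C)O)cc1` gives a limit, > 10000 nM, in this assay.
Compound 3 `COc1ccc(/C=C\c2cc(OC)c(OC)c(OC)c2)cc1OCc1ccc(CNCCNC(C)=O)cc1` gives 6400 nM in this assay.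

Compound 3 carries the lowest of the two numbers given, but compound 1 sits within the scatter of it: a 1.1-fold lower number from compound 1 to compound 3 (0.06 log units; within the scatter). The read-out of compound 2 is a limit and not a number, and the limit of > 10000 nM in this assay, at which 1 of the 3 values shown sits, is the only such case among the three. The steps that touch compound 2 therefore only set floors: an at least 1.3-fold higher number from compound 1 to compound 2 (0.13 log units; that floor lies within the scatter) and an at least 1.5-fold lower number from compound 2 to compound 3 (0.19 log units; that floor lies within the scatter), both within the scatter.

Compound 4 `COc1ccc(/C=C\c2cc(OC)c(OC)c(OC)c2)cc1OCc1ccc(CNCCN(C)C)cc1` differs from compound 3 by dimethylamino in place of acetamido on a saturated chain carbon, two bonds along the chain from an amine nitrogen. Going by the values given here, no measured step makes this exchange; the nearest comparison, from compound 1 to compound 3, replaced one amine-bearing tail with the acetamidoethyl one without moving beyond the scatter. On that basis a step of no size beyond the scatter is expected, a 1.1-fold lower number from compound 3 to compound 4 (0.03 log units; within the scatter). Compound 4 is therefore estimated at 6000 nM, with a range from 2500 nM to 15000 nM.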

Compound 4, half-maximal inhibitory concentration: 9400 nM
The estimate for compound 4 lay 1.6-fold (0.19 log units) below the measured number, within the range that was stated.
By their numbers in this assay, from the lowest: compounds 3, 1 and 4 (each within the scatter of the next). At a limit, above all of these: compound 2.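

The exchange of acetamido for dimethylamino, on a saturated chain carbon two bonds along the chain from an amine nitrogen, gives in this assay a 1.5-fold higher number from compound 3 to compound 4 (0.17 log units; within the scatter), so the amide hydrogen-bond donor can leave this position without a step beyond the scatter. The exchange of the whole tail gives a 1.3-fold higher number from compound 1 to compound 4 (0.11 log units; within the scatter), and the step from the limit sets only a floor, an at least 1.0-fold lower number from compound 2 to compound 4 (0.02 log units; that floor lies within the scatter). Compound 2 thus remains a limit and not a number: the limit of > 10000 nM in this assay, at which 1 of the 4 values shown sits.

Going by these compounds alone, no step among the compounds that carry numbers lies beyond the scatter. Going by these compounds, whether a pyrrolidine or a guanidine in place of dimethylamino, or a longer chain carrying it, would give such a step stays open.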